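The source may report more compounds than this note shows. Statements on the series, on what has been measured and on what is new or still open speak of the compounds shown alone.

In a functional assay on SMMC-7721 cells (Homo sapiens) for antiproliferative activity, read by MTT assay, with a stated time of 48 h (on this read-out higher numbers stand for weaker inhibition and lower numbers for stronger inhibition), compound 1 `CC(C)=CCC[C@]1(C)/C=C/[C@@H](OC(=O)C=C(C)C)[C@](C)(O)/C=C/C(=O)/C(CN(C)C)=C\C1` gives 820 nM and compound 2 `CC(C)=CCC[C@]1(C)/C=C/[C@@H](OC(=O)C=C(C)C)[C@](C)(O)/C=C/C(=O)/C(CN2CCN(C)CC2)=C\C1` gives 2940 nM, the higher of the two numbers. Compound 3 `COCOC/C1=C/C[C@](C)(CCC=C(C)C)/C=C/[C@@H](OC(=O)C=C(C)C)[C@](C)(O)/C=C/C1=O` differs from compound 2 by one change: methoxymethoxy in place of 4-methylpiperazin-1-yl on a saturated chain carbon bound to a double-bonded ring carbon. In words, methoxymethoxy stands in place of 4-methylpiperazin-1-yl on a saturated chain carbon bound to a double-bonded ring carbon. Among the measured compounds shown here, the only measured step at this place is a 3.6-fold higher number from compound 1 to compound 2 (0.55 log units; beyond the scatter), which is modest, and no measured compound carries a group without nitrogen there. The expected step is therefore small, with no change beyond the scatter expected in this assay: a 1.6-fold lower number from compound 2 to compound 3 (0.21 log units; within the scatter). For compound 3 the estimate is 1800 nM, with an expected range of 600 nM to 6000 nM.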

Compound 3, half-maximal inhibitory concentration: 3250 nM
The estimate for compound 3 lay 1.8-fold (0.26 log units) below the measured number; low and high end bracket the measured number.
By their numbers in this assay, from the lowest: compound 1; then compounds 2 and 3 (each within the scatter of the next).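

In this assay the place on a saturated chain carbon bound to a double-bonded ring carbon now holds a group without nitrogen: methoxymethoxy gives a 1.1-fold higher number from compound 2 to compound 3 (0.04 log units; within the scatter) against 4-methylpiperazin-1-yl and (a 4.0-fold higher number from compound 1 to compound 3 (0.60 log units; beyond the scatter)) against dimethylamino. Nitrogen in this group therefore does not by itself set the number, as compound 2 matches compound 3 within the scatter and only compound 1 stands apart. No measurement on hand accounts for this. From the compounds shown here alone, whether diethylamino, morpholin-4-yl or a carboxylic acid here would read nearer compound 1 or compound 3 stays open.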